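The source may report more compounds than this note shows. Statements on the series, on what has been measured and on what is new or still open speak of the compounds shown alone.

Measured so far in an ADME assay on Caco-2 cells (Homo sapiens) for permeability, read by LC-MS, in the apical to basolateral direction, with a stated time of 60 min, at pH 6.5; a higher number here means that the compound crosses the layer faster, a lower number that the compound crosses the layer more slowly:
- compound 1 `O=C(NCc1cc(Cl)ccc1-n1cnnn1)[C@@H]1C[C@@H]2C[C@@H]2N1C(=O)[C@H](O)Cn1cccn1`: 0.45 10^-6 cm/s
- compound 2 `CC1(C[C@@H](O)C(=O)N2N=CC[C@H]2C(=O)NCc2cc(Cl)ccc2-n2cnnn2)CC1`: 9.5 10^-6 cm/s

Compound 1 stands lowest of the two numbers, and compound 2 lies higher by a gap beyond the usual scatter. The two compounds do not differ in one place only, so their values cannot tie that gap to any single structural change.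

The next compound for this assay is compound 3 `O=C(NCc1cc(Cl)ccc1-n1cnnn1)[C@@H]1C[C@@H]2C[C@@H]2N1C(=O)[C@H](O)C1CCCCC1`, not yet measured. Its difference from compound 1 is cyclohexyl in place of (1H-pyrazol-1-yl)methyl on a saturated chain carbon bound to a carbonyl carbon and an oxygen on a saturated carbon.

Among the measured compounds shown here, a rise beyond the scatter is expected, though the basis is thin: compound 1 at 0.45 10^-6 cm/s sits low, and the only higher reference is compound 2 at 9.5 10^-6 cm/s. The expected size is a 6.7-fold higher number from compound 1 to compound 3 (0.82 log units; beyond the scatter). For compound 3 the estimated value is 3 10^-6 cm/s, with an expected range of 1 10^-6 cm/s to 9 10^-6 cm/s.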

Compound 3, apparent permeability: 16 10^-6 cm/s
Beside the measured number, compound 3's estimate is 5.3-fold (0.73 log units) below it, outside the stated range (above it).
By their numbers in this assay, from the lowest: compound 1; then compounds 2 and 3 (each within the scatter of the next).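

In this assay, the saturated chain carbon bound to a carbonyl carbon and an oxygen on a saturated carbon emerges as a position where one change moves the read-out strongly: cyclohexyl in place of (1H-pyrazol-1-yl)methyl gives a 36-fold higher number from compound 1 to compound 3 (1.55 log units; beyond the scatter) on an otherwise unchanged structure. This is the only step shown that ties a gap in this read-out to a single structural change, and it swaps a five-membered aromatic ring with 2 hetero atoms and 2 hydrogen-bond acceptors for a six-membered non-aromatic ring of carbon only, with 6 heavy atoms both leaving and entering. No measured evidence on the origin of this step is available.

The compounds shown do not separate the loss of the two pyrazole nitrogens from the change in ring type or in the link to the chain, and a phenyl or a (cyclohexyl)methyl group on the same carbon would bear on that question. Also open, as far as these compounds go, is how an amine or a carboxylic acid carried on the cyclohexyl ring would read, and whether the same exchange gives a step of similar size on the core of compound 2.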